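The source may report more compounds than this note shows. Statements on the series, on what has been measured and on what is new or still open speak of the compounds shown alone.

Compound 1, `CC(=NNC(=S)Nc1ccccc1F)c1ccccn1`: 5 nM
Compound 2, `CC(=NNC(S)=Nc1ccccc1Cl)c1ccccn1`: 2.6 nM

In a functional assay on U-87MG ATCC cells (Homo sapiens) for cytotoxicity, read by MTT assay, with a stated time of 48 h (a higher number here means a weaker inhibitor, a lower number a stronger inhibitor), compound 1 gives 5 nM, and compound 2 gives 2.6 nM. Compound 1 carries the higher of these two numbers, but the gap to compound 2 lies within the usual scatter of the method, so the two cannot be told apart on these data. For the measured compounds named here, no step between measured compounds that differ in a single place is available, so nothing measured here speaks directly to the size of a substituent swap on this core.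

Compound 3, `CC(=NNC(=S)Nc1ccccc1[N+](=O)[O-])c1ccccn1`, is not yet measured. It differs from compound 1 as follows: nitro in place of fluoro on an aromatic carbon. Going by the values given here, with no measured step of this kind to lean on, the expectation for compound 3 rests on compound 1 alone, whose value is 5 nM. Compound 3 is expected to give about 6 nM, with a plausible range from 2 nM to 20 nM. This expectation means a step of a 1.2-fold higher number from compound 1 to compound 3 (0.08 log units; within the scatter), no larger than the scatter.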

Compound 3, half-maximal inhibitory concentration: 4.3 nM
Compound 3: middle estimate off by 1.4-fold (0.14 log units), on the high side, and the stated range covers the measured number.
By their numbers in this assay, from the lowest: compounds 2, 3 and 1 (each within the scatter of the next).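

In this assay, for the compounds shown here, the step of a 1.2-fold lower number from compound 1 to compound 3 (0.07 log units; within the scatter) is the first measured change in a single place on this core, and it stays within the scatter. Nitro, with its 3 heavy atoms and 2 hydrogen-bond acceptors, thus stands in place of fluoro, with 1 heavy atom and no such acceptor, on an aromatic carbon ortho to a large group, and the two compounds cannot be told apart on these numbers. No measurement is at hand that could explain this result.

The compounds shown leave open whether the number would hold with an amine, a carboxylic acid or a methoxy group at this place, or with plain hydrogen. They also leave open whether the same swap on another carbon of this ring would give an equally small step.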